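The source may report more compounds than this note shows. Statements on the series, on what has been measured and on what is new or still open speak of the compounds shown alone.

Working notes on the series. Compound 1 `CCCCCN1CCC(NC(=O)c2cc(Cl)c(N)cc2OC)CC1` is the reference point here. Among the measured compounds shown here, in an assay on HEK293 cells for displacement of a labelled ligand from 5-hydroxytryptamine receptor 4 (Homo sapiens), read by scintillation counting (a higher number here means a weaker inhibitor, a lower number a stronger inhibitor), compound 1 gives 100 nM, the lowest of the two numbers so far. Compound 2 `COc1cc(N)c(Cl)cc1C(=O)NC1CCN(CCN2C(=O)c3ccccc3C2=O)CC1` differs in the chain, and in this assay compound 2 gives 7940 nM; the gap from compound 1 to compound 2 lies well beyond the scatter, so chain elaboration in this set has so far cost potency sharply.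

Compound 3 `COc1cc(N)c(Cl)cc1C(=O)NC1CCN(CCN2CCN(S(C)(=O)=O)CC2)CC1` has not been measured. Relative to compound 1 the change is 4-(methylsulfonyl)piperazin-1-yl in place of propyl on a saturated chain carbon, two bonds along the chain from an amine nitrogen in a ring. For the measured compounds named here, no measured pair in the set mirrors this exact step. Because compound 2 gives 7940 nM, a weaker number is expected for compound 3 once a ring-bearing terminal group replaces the plain chain. For compound 3 the step of a 10-fold higher number from compound 1 to compound 3 (1.00 log units; beyond the scatter) is expected to be upward, beyond the scatter, though smaller than the gap to compound 2. The estimate for compound 3 is 1000 nM, with a range from 200 nM to 5000 nM.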

Compound 3, inhibition constant: 126 nM
For compound 3 the middle estimate is 7.9-fold (0.90 log units) above the measured one; the whole stated range lies above it.
By their numbers in this assay, from the lowest: compounds 1 and 3 (each within the scatter of the next); then compound 2.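

In this assay the change to 4-(methylsulfonyl)piperazin-1-yl in place of propyl, on a saturated chain carbon, two bonds along the chain from an amine nitrogen in a ring, gives a 1.3-fold higher number from compound 1 to compound 3 (0.10 log units; within the scatter) so this position accepts a much larger group carrying a six-membered non-aromatic ring. The earlier reading that chain elaboration costs potency thus holds for compound 2 at 7940 nM but not for compound 3 at 126 nM even though both carry a ring-bearing terminal group. What matters at this position is therefore the particular terminal group, not elaboration as such.

As far as these compounds go, whether a longer chain, or a terminal amine or carboxylic acid in place of the methylsulfonyl group, would stay within the scatter of compound 1 remains open. No supporting data are at hand to explain the gap between the two terminal groups.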